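This account rests on a few compounds, and the source may have more. Where it says the series, first, only, none or still open, it means among the compounds named here.

Compounds measured in a functional assay on MCF7 cells (Homo sapiens) for inhibition, read by resazurin assay, with a stated time of 72 h; on this read-out lower numbers stand for stronger inhibition and higher numbers for weaker inhibition:
compound 1, `CCOc1ccc(C2C(C3CC3)C(=O)N2c2cc(OC)c(OC)c(OC)c2)cc1`, gives 131 nM
compound 2, `COc1ccc(C2C(C3CC3)C(=O)N2c2cc(OC)c(OC)c(OC)c2)cc1`, gives 120 nM
compound 3, `CCSc1ccc(C2C(Oc3ccccc3)C(=O)N2c2cc(OC)c(OC)c(OC)c2)cc1`, gives 210 nM

Compound 1 stands second highest of the three numbers. Its nearest neighbour is compound 2, reached by a 1.1-fold lower number from compound 1 to compound 2 (0.04 log units; within the scatter), a change within the scatter; compound 3 lies furthest, and the two values of compound 1 and compound 3 also sit within the scatter of each other, so no ordering among the three is claimed.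

Compound 4, `CCOc1ccc(C2C(O)C(=O)N2c2cc(OC)c(OC)c(OC)c2)cc1`, has not been measured. It differs from compound 1 as follows: hydroxy in place of cyclopropyl on a saturated ring carbon. Going by the values given here, the only measured step, the one from compound 1 to compound 2, concerns the ethoxy group on the aromatic ring and says nothing about the saturated ring carbon of the shared core. Among the compounds with values here, compound 3 carries a phenoxy group at that same ring carbon, but it also differs from compound 1 in the para group on the aryl ring, so no single-place step to it exists; its value only shows that an oxygen-linked group at this carbon is compatible with a number of the same order as compound 1. On this thin basis the expectation for compound 4 is a step of a 1.9-fold higher number from compound 1 to compound 4 (0.28 log units; within the scatter), modest and uncertain in direction, with the range kept wide. The estimated value for compound 4 is 250 nM, between 60 nM and 1000 nM.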

Compound 4, half-maximal inhibitory concentration: 7 nM
Compound 4: the middle estimate sits 36-fold (1.55 log units) above what was measured; the whole stated range lies above it.
By their numbers in this assay, from the lowest: compound 4; then compounds 2, 1 and 3 (each within the scatter of the next).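

In this assay, hydroxy in place of cyclopropyl on the saturated ring carbon gives a 19-fold lower number from compound 1 to compound 4 (1.27 log units; beyond the scatter) and is the only step shown that lies beyond the scatter, so this carbon is a place where a single change moves the read-out strongly. Going by these compounds alone, the one earlier step, at the ethoxy group on the aromatic ring, was a 1.1-fold lower number from compound 1 to compound 2 (0.04 log units; within the scatter) and gave no sign of such sensitivity anywhere, while compound 3 differs from compound 1 in more than one place and cannot isolate this carbon. The compounds shown carry no evidence on why the exchange of cyclopropyl for hydroxy has an effect of this size.

As far as these compounds go, it remains open whether the step belongs to the hydroxy group itself or to the departure of cyclopropyl, a question that a plain hydrogen, an amine or an acetate ester at the same carbon would help to separate. From the compounds shown here alone, it also remains open whether the step carries over to other aryl groups, as hydroxy at this carbon appears here only with the 4-ethoxyphenyl group.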